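The compounds below may be only part of what the source reports. "The series", "measured", "known", "first", "only" and "open" are said of these compounds alone.

Working notes on the series, single variable position on the shared core.

Compound 1 `CCOC(=O)c1cnc(NN2C(=O)C=C(C)C2=O)nc1C(F)(F)F` carries a trifluoromethyl at the varied position and in a functional assay on Jurkat cells (Homo sapiens) for inhibition (on this read-out lower numbers stand for stronger inhibition and higher numbers for weaker inhibition), compound 1 gives 2000 nM. Compound 2 `CCOC(=O)c1cnc(NN2C(=O)C=C(C)C2=O)nc1C(F)(F)C(F)(F)F` carries a 1,1,2,2,2-pentafluoroethyl instead, and in this assay compound 2 gives 200 nM; the step is a 10-fold lower number from compound 1 to compound 2 (1.00 log units; beyond the scatter). Compound 3 `CCOC(=O)c1cnc(NN2C(=O)C=C(C)C2=O)nc1-c1cccs1` carries a thiophen-2-yl, and in this assay compound 3 gives 140 nM. Compound 3 stands at the low end of the three numbers: nearest is compound 2 (a 1.4-fold lower number from compound 2 to compound 3 (0.15 log units; within the scatter), within the scatter), furthest is compound 1 (a 14-fold lower number from compound 1 to compound 3 (1.15 log units; beyond the scatter)).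

Compound 4 `CCOC(=O)c1cnc(NN2C(=O)C=C(C)C2=O)nc1-c1cc2ccccc2s1` differs from compound 3 in one place: 1-benzothiophen-2-yl in place of thiophen-2-yl on an aromatic carbon. Going by the values given here, no measured step sets a thiophen-2-yl against a 1-benzothiophen-2-yl, so the precedent is indirect. The two steps into compound 3, a 14-fold lower number from compound 1 to compound 3 (1.15 log units; beyond the scatter) and a 1.4-fold lower number from compound 2 to compound 3 (0.15 log units; within the scatter), show the thiophen-2-yl holding the low numbers, and the one enlargement at this position, a 10-fold lower number from compound 1 to compound 2 (1.00 log units; beyond the scatter), went downward. From this a modest step downward in this assay or none beyond the scatter is expected. Compound 4 is estimated at 100 nM, with a range of 30 nM to 400 nM, which is an expected step of a 1.4-fold lower number from compound 3 to compound 4 (0.15 log units; within the scatter).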

Compound 4, half-maximal inhibitory concentration: 800 nM
Beside the measured number, compound 4's estimate is 8.0-fold (0.90 log units) below it; the measured number lies above the stated range.
By their numbers in this assay, from the lowest: compounds 3 and 2 (each within the scatter of the next); then compound 4; then compound 1.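

Enlarging the thiophen-2-yl to a 1-benzothiophen-2-yl on this aromatic carbon raises the number in this assay, with a 5.7-fold higher number from compound 3 to compound 4 (0.76 log units; beyond the scatter), so the downward step seen on going from trifluoromethyl to 1,1,2,2,2-pentafluoroethyl does not carry over to this enlargement. The 1-benzothiophen-2-yl also falls short of the 1,1,2,2,2-pentafluoroethyl, with a 4.0-fold higher number from compound 2 to compound 4 (0.60 log units; beyond the scatter), but it still improves on the trifluoromethyl, with a 2.5-fold lower number from compound 1 to compound 4 (0.40 log units; beyond the scatter), so the added six-membered aromatic ring gives up part of the gain without returning the number to that of compound 1. Nothing available on this series accounts for the rise seen with the larger group.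

The compounds shown leave open whether a phenyl or a thiophen-3-yl would stay close to the thiophen-2-yl, and whether the rise follows from the added six-membered aromatic ring itself or from how the group is attached, which a 1-benzothiophen-3-yl would test. Also open, from the compounds shown here alone, are how an amine or a carboxylic acid would read at this position, and whether the same order of groups holds when an amide replaces the ethoxycarbonyl group.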